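The source may hold more compounds than are shown below. What is called first, only, known or untested is meant among the compounds shown, and "the series" means these compounds.

Working notes on the series in an ADME assay on Akata cells (Homo sapiens) for cytotoxicity, with a stated time of 7 days; a higher number here means that more compound is tolerated, a lower number that less compound is tolerated.

Compound 3 `Nc1nc(OCC(F)(F)F)c2ncn(/C=C3/CC3(CO)CO)c2n1` sits at a limit in this assay: compound 3 gives > 20000 nM, a limit of the assay and not a number. Compound 1 `CCCCSc1nc(N)nc2c1ncn2/C=C1/CC1(CO)CO` also returns a limit in this assay, > 20000 nM. Compound 2 `CCCOc1nc(N)nc2c1ncn2/C=C1/CC1(CO)CO` likewise stops at a limit in this assay, > 20000 nM. All three values therefore stand at the limit of > 20000 nM in this assay, at which 3 of the 3 values shown sit, and the steps a step that the two limits leave unreadable from compound 1 to compound 2, a step that the two limits leave unreadable from compound 1 to compound 3 and a step that the two limits leave unreadable from compound 2 to compound 3 are unreadable in size.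

Compound 4 `CCOc1nc(N)nc2c1ncn2/C=C1/CC1(CO)CO` is not yet measured. Its change from compound 3 is methyl in place of trifluoromethyl on a saturated chain carbon bound to an oxygen on an aromatic ring. The step from compound 2 to compound 3 alters the same chain carbon bound to an oxygen on an aromatic ring, yet gives no readable size, so no direction in this assay can be drawn from it. Compound 4 is expected to stay at the limit, with a step that the limit leaves unreadable from compound 3 to compound 4 judged no larger than the scatter. Compound 4 is estimated at 30000 nM, within a range of 15000 nM to 80000 nM, most likely reported again as a limit.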

Compound 4, half-maximal cytotoxic concentration: > 20000 nM
Compound 4 ended at the assay's limit; the forecaster's own chance of this, stated with the estimate: 85%; the middle value is on the limit's open side.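

In this assay no new step can be read, as the steps to compound 4 from compound 1, compound 2 and compound 3 all join two limits: the limit of > 20000 nM in this assay, at which 4 of the 4 values shown sit. The compounds shown leave open whether any of the four differs from the others in this assay.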